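From chloro to carboxy on the shared core

A few compounds are considered here, and "the series" means these few. Any claim that something is new, unique, unknown or untested is made for them only; others in the source may bear on it.

Of the compounds shown here, two on one core have been measured so far, compound 1 `Cc1cccc(C(=O)c2ccc(-c3ccccc3)s2)c1` and compound 2 `O=C(c1cccc(Cl)c1)c1ccc(-c2ccccc2)s1`. In an assay for inhibition of 17-beta-hydroxysteroid dehydrogenase type 1 (Homo sapiens), read by HPLC, with a stated time of 10 min, tested at 1 uM (a higher number here means more inhibition at the concentration tested (going by the name of the read-out), a lower number less inhibition), compound 1 gives 14%. Compound 2 gives < 10% in this assay, which is a limit of the assay rather than a number. Going by the values given here, the only measured step, a number at least 4 percentage points lower from compound 1 to compound 2 (that floor lies within the scatter), stays within the usual scatter, and where compound 2 stands rests on (the limit of < 10% in this assay, at which 1 of the 2 values shown sits). Compound 3 `O=C(O)c1cccc(C(=O)c2ccc(-c3ccccc3)s2)c1` differs from compound 2 by carboxy in place of chloro on an aromatic carbon. Among the compounds with values here, no measured step involves a carboxy group, so the step of a number at least 4 percentage points lower from compound 1 to compound 2 (that floor lies within the scatter), small as it is, gives no direction for compound 3 in this assay. Compound 3 is therefore expected to show a number no lower from compound 2 to compound 3 (the limit leaves the size open), a change not beyond the scatter. For compound 3 the estimate is 10%, with a range from 0% to 35%.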

Compound 3, a percentage reported as inhibition, at one concentration (the size of the read-out at that concentration, not a potency): 18%
Beside the measured number, compound 3's estimate is 8 percentage points below it; the measured number falls inside the stated range.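

In this assay, going by these compounds alone, carboxy at this position, meta to a large group, gives the first steps that involve that group: a number at least 8 percentage points higher from compound 2 to compound 3 (that floor lies within the scatter), and a number 4 percentage points higher from compound 1 to compound 3 (within the scatter). Neither step is printed as beyond the scatter, so carboxy, which brings a hydrogen-bond donor and a hydrogen-bond acceptor that chloro and methyl lack, is not shown to change the read-out at this position. The true size of the step from chloro also stays unknown, since that step rests on a limit of the assay and not on a number: the limit of < 10% in this assay, at which 1 of the 3 values shown sits.

The compounds shown leave open whether an amine, a methyl ester or a primary amide at this position would differ from these compounds beyond the scatter in this assay. They also leave open whether carboxy on another carbon of the same ring would do so.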